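Pentynyl Ether to Methylcyclopentyl Ether at the Same Oxygen

The source may report more compounds than this note shows. Statements on the series, on what has been measured and on what is new or still open speak of the compounds shown alone.

Compound 1 `Nc1ccc2cccc(OC3CCCCC3)c2n1` in an assay on cells with melanin-concentrating hormone receptor 1 (Homo sapiens) as the target, read by radioligand binding (a higher number here means a weaker inhibitor, a lower number a stronger inhibitor), gives 361 nM.
Compound 2 `CCCCOc1cccc2ccc(N)nc12` gives 789 nM.
Compound 3 `CCC#CCOc1cccc2ccc(N)nc12` gives only a limit, > 2000 nM.

Compound 3 therefore sits at the limit of > 2000 nM in this assay, at which 1 of the 3 values shown sits, and has no exact number of its own. The change to compound 4 `CC1CCC(Oc2cccc3ccc(N)nc23)C1` is 3-methylcyclopentyl in place of pent-2-yn-1-yl on an oxygen on an aromatic ring: an open chain with a triple bond leaves and a small ring enters. Two measured steps speak to this. The step of an at least 5.5-fold higher number from compound 1 to compound 3 (0.74 log units; beyond the scatter) ran from a ring to this chain and weakened binding, and an at least 2.5-fold higher number from compound 2 to compound 3 (0.40 log units; beyond the scatter) showed the triple-bond chain weaker than a plain chain. Since compound 4 carries a ring like compound 1, compound 4 is expected to move back toward compound 1, an estimated step of an at least 4.0-fold lower number from compound 3 to compound 4 (0.60 log units; beyond the scatter). For compound 4 the estimate in this assay is 500 nM, within 200 nM to 1500 nM.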

Compound 4, half-maximal inhibitory concentration: 823 nM
Estimate against measurement, compound 4: 1.6-fold (0.22 log units) below, within the range that was stated.
By their numbers in this assay, from the lowest: compound 1; then compounds 2 and 4 (each within the scatter of the next). At a limit, above all of these: compound 3.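

Replacing the triple-bond chain with 3-methylcyclopentyl gives an at least 2.4-fold lower number from compound 3 to compound 4 (0.38 log units; beyond the scatter), but this step is only a minimum: the limit of > 2000 nM in this assay, at which 1 of the 4 values shown sits.
A ring alone does not recover the binding of compound 1, as 3-methylcyclopentyl in place of cyclohexyl gives a 2.3-fold higher number from compound 1 to compound 4 (0.36 log units; beyond the scatter).
Nor does this ring beat an open chain, as 3-methylcyclopentyl in place of butyl gives a 1.0-fold higher number from compound 2 to compound 4 (0.02 log units; within the scatter).

Still open, on these data alone, is whether a larger ring such as cycloheptyl, or a cyclohexyl ring carrying an amine, would bind more strongly than the plain cyclohexyl of compound 1.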